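The source may hold more compounds than are shown below. What is called first, only, known or untested is meant among the compounds shown, and "the series" means these compounds.

Going by the values given here, in a functional assay on the whole organism with Mus musculus as the target, in the rotarod test (on this read-out lower numbers stand for an effect already at smaller amounts and higher numbers for an effect only at larger amounts of compound), compound 2 `CCCC(=O)NCC(=O)N(C)c1ccc(Cl)cc1C(=O)c1ccccc1Cl` gives 55.2 mg/kg, the only number recorded. Compound 1 `NC(C(=O)NCC(=O)Nc1ccc(Cl)cc1C(=O)c1ccccc1)c1ccccc1` reaches only the limit of the assay, > 100 mg/kg. Compound 3 `CC(=O)NCC(=O)Nc1ccc(Cl)cc1C(=O)c1ccccc1Cl` likewise stops at the limit, > 100 mg/kg. Among the compounds with values here, two of the three results thus sit at the limit of > 100 mg/kg in this assay, at which 2 of the 3 values shown sit, so no step between measured compounds can be drawn, and compound 2 stands alone as the single numeric result. Compound 4 `CN(C(=O)CNC(=O)CN1CCN(c2ccccc2)CC1)c1ccc(Cl)cc1C(=O)c1ccccc1Cl` has not yet been measured; it differs from compound 2 in one place: 4-phenylpiperazin-1-yl in place of ethyl on a saturated chain carbon bound to a carbonyl carbon. Within the data shown here, with no comparable pair to draw on, the expected change is a 1.2-fold lower number from compound 2 to compound 4 (0.09 log units; within the scatter), a step no larger than the usual scatter. Compound 4 is therefore estimated at 45 mg/kg, with a range from 15 mg/kg to 100 mg/kg.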

Compound 4, dose for half-maximal effect: > 100 mg/kg
Compound 4 ended at the assay's limit; the forecaster's own chance of this, stated with the estimate: 30%; middle value at least 2.2-fold (0.34 log units) from the limit.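

In this assay, 4-phenylpiperazin-1-yl in place of ethyl on a saturated chain carbon bound to a carbonyl carbon gives an at least 1.8-fold higher number from compound 2 to compound 4 (0.25 log units; that floor lies within the scatter), so this position now has one step, known only by its floor. Compound 4 gives > 100 mg/kg, which is a limit of the assay and not a number. Compound 2 thus remains the only numeric result: the limit of > 100 mg/kg in this assay, at which 3 of the 4 values shown sit.

As far as these compounds go, the true size of this step stays open. So does whether dimethylamino or a longer chain in place of ethyl on this carbon would give a number within the assay's range.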